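Pyridin-4-yl in place of phenyl on compound 1

The source may hold more compounds than are shown below. What is called first, only, known or untested is meant among the compounds shown, and "the series" means these compounds.

In a functional assay on MGC-803 cells (Homo sapiens) for antiproliferative activity, read by CCK-8 assay, with a stated time of 72 h (a lower number here means a stronger inhibitor, a higher number a weaker inhibitor), compound 1 (`Nc1ccccc1NC(=O)c1ccc(CSC(=S)N2CCN(c3ccccc3)CC2)cc1`) gives 2140 nM and compound 2 (`CCN(Cc1ccncc1)C(=S)SCc1ccc(C(=O)Nc2ccccc2N)cc1`) gives 1370 nM as its value, so the two stand within the scatter of each other. Compound 3 (`Nc1ccccc1NC(=O)c1ccc(CSC(=S)N2CCN(c3ccncc3)CC2)cc1`) carries pyridin-4-yl in place of phenyl on an amine nitrogen in a ring. Going by the values given here, no measured pair differing in one place is available to size this change. No shift beyond the scatter is expected in this assay for this exchange, and the expected step (a 1.3-fold lower number from compound 1 to compound 3 (0.10 log units; within the scatter)) is correspondingly small. Compound 3 is estimated at 1700 nM (expected range 700 nM to 4000 nM).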

Compound 3, half-maximal inhibitory concentration: 1580 nM
For compound 3 the middle estimate is 1.1-fold (0.03 log units) above the measured one; measured number inside the range.
By their numbers in this assay, from the lowest: compounds 2, 3 and 1 (each within the scatter of the next).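

In this assay, pyridin-4-yl in place of phenyl on the amine nitrogen in a ring gives a 1.4-fold lower number from compound 1 to compound 3 (0.13 log units; within the scatter), the first single-place step readable in this series. At this position, the exchange adds one hydrogen-bond acceptor without moving the number beyond the scatter. No evidence is available that bears on this result.

The compounds shown leave open whether a different group on this amine nitrogen, such as benzyl, methyl or an acetyl group, would give a step beyond the scatter. Also open, going by these compounds, is what a methoxy group on the pyridin-4-yl ring would do.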